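Swapping the Benzyl Substituent on a Bombesin Receptor Agonist

The compounds below may be only part of what the source reports. "The series", "measured", "known", "first", "only" and "open" are said of these compounds alone.

Three compounds sharing a biphenyl carboxylic acid attached to an imidazole core have been tested in an in vitro functional assay on cells for agonist activity at Bombesin receptor subtype-3 (Mus musculus), read by luminescence and calcium flux; on this read-out higher numbers stand for an effect only at larger amounts of compound and lower numbers for an effect already at smaller amounts. Compound 1 `CCCCc1cnc(C(CC)Cc2ccc(-c3ccccc3C(=O)O)cc2)[nH]1` gives 340 nM. Compound 2 `COc1ccccc1Cc1cnc(CCc2ccc(-c3ccccc3C(=O)O)cc2)[nH]1` gives 163 nM, the lowest of the two numbers available, with the value of compound 1 standing beyond the usual scatter above it. Compound 3 `CCCCc1cnc(Cc2ccc(-c3ccccc3C(=O)O)cc2)[nH]1` gives only a limit of the assay, > 10000 nM, and no number.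

Compound 4 `O=C(O)c1ccccc1-c1ccc(CCc2ncc(Cc3ccc(Cl)cc3)[nH]2)cc1` has not yet been measured. It differs from compound 2 in one place: 4-chlorophenyl in place of 2-methoxyphenyl on a saturated chain carbon bound to an aromatic carbon. Among the measured compounds shown here, no measured pair shows what such a swap does here, so the expectation rests on compound 2 alone. Because compound 2 gives 163 nM, compound 4 is expected to fall near it, with a step from compound 2 to compound 4 of a 1.2-fold higher number from compound 2 to compound 4 (0.09 log units; within the scatter), which would not count as more than the scatter. The estimate for compound 4 in this assay is 200 nM, between 50 nM and 800 nM.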

Compound 4, half-maximal effective concentration: 102 nM
Compound 4: the middle estimate sits 2.0-fold (0.29 log units) above what was measured; measured number inside the range.
By their numbers in this assay, from the lowest: compounds 4 and 2 (each within the scatter of the next); then compound 1. At a limit, above all of these: compound 3.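

In this assay, replacing 2-methoxybenzyl with 4-chlorobenzyl gives a 1.6-fold lower number from compound 2 to compound 4 (0.20 log units; within the scatter), so this assay does not separate the two groups. The group that leaves carries a hydrogen-bond acceptor and the group that enters carries none, so for this pair, activity in this range does not depend on that acceptor. Among the compounds shown here, this is the first sign that the place, a saturated chain carbon bound to an aromatic carbon, can take a different substituent on the ring without a change beyond the scatter, although no measurement here explains why the two groups behave alike.

From the compounds shown here alone, whether a plain unsubstituted benzyl would behave the same remains open. So does the outcome for a ring carrying an amine or a carboxylic acid, or for a longer chain between this ring and the core.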